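The compounds below may be only part of what the source reports. "The series", "measured", "known", "first", "only" and "open" are said of these compounds alone.

In a functional assay on cells (Cancer cell lines, Homo sapiens) for cytotoxicity, read by sulforhodamine B assay, with a stated time of 48 h (on this read-out lower numbers stand for stronger inhibition of growth and higher numbers for weaker inhibition of growth), compound 3 `COc1ccc(C2=NN(C3=NC(=O)/C(=C4\C(=O)Nc5ccc(Br)cc54)S3)C(c3ccc(OC)cc3)C2)cc1` gives 200 nM. It sits level with compound 1 `COc1ccc(C2CC(c3ccccc3)=NN2C2=NC(=O)/C(=C3\C(=O)Nc4ccc(Br)cc43)S2)cc1`, which gives 200 nM; together they hold the lowest of the three numbers, and no change at the digits printed from compound 1 to compound 3 (within the scatter) for methoxy in place of hydrogen on an aromatic carbon. Compound 2 `COc1ccc(C2=NN(C3=NC(=O)/C(=C4\C(=O)Nc5ccccc54)S3)C(c3ccc(OC)cc3)C2)cc1` gives 88100 nM, so a 440-fold lower number from compound 2 to compound 3 (2.64 log units; beyond the scatter) shows how much bromo in place of hydrogen on an aromatic carbon matters here. Compound 4 `COc1ccc(C2=NN(C3=NC(=O)/C(=C4\C(=O)Nc5ccc(Cl)cc54)S3)C(c3ccc(OC)cc3)C2)cc1` carries chloro in place of bromo on an aromatic carbon. Going by the values given here, only the step from compound 2 to compound 3 bears on this change: a halogen remains, so in this assay a small to moderate rise is expected rather than a large one. Compound 4 is therefore expected to give 400 nM, between 120 nM and 3000 nM. The expected step is a 2.0-fold higher number from compound 3 to compound 4 (0.30 log units; within the scatter).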

Compound 4, concentration for 50% growth inhibition: 200 nM
Estimate against measurement, compound 4: 2.0-fold (0.30 log units) above; measured number inside the range.
By their numbers in this assay, from the lowest: compounds 1, 3 and 4 (each within the scatter of the next); then compound 2.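

In this assay, chloro in place of bromo gives (no change at the digits printed from compound 3 to compound 4 (within the scatter)), and chloro in place of hydrogen gives (a 440-fold lower number from compound 2 to compound 4 (2.64 log units; beyond the scatter)). The large drop in the number at this position is therefore not confined to bromo, as chloro shows it too. No measurement at hand explains why these two halogens match here.

Still open, from the compounds shown here alone, is whether fluoro or iodo at this position would match compound 3 and compound 4. The same question stands for a group without a halogen, such as an amine or a carboxylic acid.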